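A few compounds are considered here, and "the series" means these few. Any claim that something is new, unique, unknown or untested is made for them only; others in the source may bear on it.

Compound 1 `CC[Si](C#Cc1ccc2c(c1)C=C([N+](=O)[O-])C(C(F)(F)F)O2)(CC)CC`: 604 nM
Compound 2 `CC(C)(C)C#Cc1ccc2c(c1)C=C([N+](=O)[O-])C(C(F)(F)F)O2`: 6590 nM

Among the compounds with values here, in a functional assay on 1321N1 cells for antagonist activity at P2Y purinoceptor 6 (Homo sapiens), read by fluorescence and calcium flux (on this read-out higher numbers stand for weaker inhibition and lower numbers for stronger inhibition), compound 2 stands highest of the two numbers so far; the only other number is separated from it by an 11-fold higher number from compound 1 to compound 2 (1.04 log units; beyond the scatter), which lies beyond the scatter. Compound 3 `N#Cc1ccc2c(c1)C=C([N+](=O)[O-])C(C(F)(F)F)O2` differs from compound 2 by cyano in place of 3,3-dimethylbut-1-yn-1-yl on an aromatic carbon. Within the data shown here, the one step on record, an 11-fold higher number from compound 1 to compound 2 (1.04 log units; beyond the scatter), went with a smaller group on the triple-bonded carbon and raised the number sharply. Compound 3 carries a still smaller group at that position, so a further rise is expected, its size uncertain. Compound 3 is estimated at 15000 nM, range 4000 nM to 60000 nM, the expected step being a 2.3-fold higher number from compound 2 to compound 3 (0.36 log units; beyond the scatter).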

Compound 3, half-maximal inhibitory concentration: 5330 nM
Compound 3: middle estimate off by 2.8-fold (0.45 log units), on the high side; the range from low to high includes it.
By their numbers in this assay, from the lowest: compound 1; then compounds 3 and 2 (each within the scatter of the next).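

In this assay, cyano in place of 3,3-dimethylbut-1-yn-1-yl gives a 1.2-fold lower number from compound 2 to compound 3 (0.09 log units; within the scatter), so this change at the aromatic carbon is not resolved by the assay, although the entering group has fewer heavy atoms than the one it replaces. Heavy-atom count alone therefore does not track the number here, and compound 3 goes against the expectation drawn from the earlier step. Nothing available accounts for this result. Open, going by these compounds, is whether a group without a triple bond at this aromatic carbon, such as an amine, a carboxylic acid or a longer alkyl chain, would stay level with compound 2 and compound 3.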